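Exchanging an Amine on a Thiocarbonyl Carbon in Two Cores

This account rests on a few compounds, and the source may have more. Where it says the series, first, only, none or still open, it means among the compounds named here.

Four compounds share a thiocarbonyl carbon that carries a sulfur and an amine group, and that amine group is exchanged in the same way on two different cores. Compound 1 `COc1ccc2occ(CSC(=S)N(C(C)C)C(C)C)c(=O)c2c1` and compound 3 `COc1ccc2occ(CSC(=S)N3CCCC3)c(=O)c2c1` share one core. Compound 2 `CC(C)N(C(=S)SCc1oc2ccccc2c(=O)c1Cl)C(C)C` and compound 4 `O=c1c(Cl)c(CSC(=S)N2CCCC2)oc2ccccc12` share another; the difference between the two cores is not broken down here.

All of them were, or will be, tested in a functional assay on MCF7 cells (Homo sapiens) for antiproliferative activity, read by MTT assay, with a stated time of 72 h; a higher number here means a weaker inhibitor, a lower number a stronger inhibitor. For compound 1 the result is only a limit of the assay, > 40000 nM. Compound 3 gives 34100 nM. The change from compound 1 to compound 3 is pyrrolidin-1-yl in place of diisopropylamino on a thiocarbonyl carbon, and it made a step of an at least 1.1-fold lower number from compound 1 to compound 3 (0.06 log units; that floor lies within the scatter). Two of the three measured values sit at the limit of > 40000 nM in this assay, at which 2 of the 3 values shown sit, so the measured step can be given only as a floor.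

For compound 2 the result is likewise only a limit of the assay, > 40000 nM. Compound 4 differs from compound 2 by pyrrolidin-1-yl in place of diisopropylamino on a thiocarbonyl carbon, the same change as before, made on the other core. Because an at least 1.1-fold lower number from compound 1 to compound 3 (0.06 log units; that floor lies within the scatter) lies within the usual scatter, the step expected from the same change is a number no higher from compound 2 to compound 4 (the limit leaves the size open). Compound 4 is therefore estimated at 40000 nM, with a real chance that the measurement again returns only a limit.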

Compound 4, half-maximal inhibitory concentration: 2300 nM
Beside the measured number, compound 4's estimate is 17-fold (1.24 log units) above it; measured number below the stated range.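

In this assay, pyrrolidin-1-yl in place of diisopropylamino on a thiocarbonyl carbon gives an at least 17-fold lower number from compound 2 to compound 4 (1.24 log units; beyond the scatter), so on this core the exchange is followed by a large drop in the number, which means a stronger inhibitor. The same exchange on the core of compound 1 shows no drop beyond the scatter, yet these results do not show that the change carries over differently on the two cores: the same change on two cores in this assay, an at least 1.1-fold lower number (0.06 log units; that floor lies within the scatter) from compound 1 to compound 3 and an at least 17-fold lower number (1.24 log units; beyond the scatter) from compound 2 to compound 4; the limit leaves it open whether they differ. Compound 1 and compound 2 are each recorded only as a limit, so the true size of neither step is known, and the size of the step on either core remains uncertain: the limit of > 40000 nM in this assay, at which 2 of the 4 values shown sit.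

The compounds shown leave open whether this result is particular to pyrrolidin-1-yl or whether other amines on the thiocarbonyl carbon, such as piperidin-1-yl, morpholin-4-yl or dimethylamino, would be followed by a similar drop. They also leave open which feature of the core of compound 4 goes with its stronger result, since compound 3 and compound 4 differ in more than one place, and a further core would be needed to test how widely the exchange applies.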